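The source may hold more compounds than are shown below. What is called first, only, known or untested is meant among the compounds shown, and "the series" means these compounds.

Compound 1 `CC(C)n1nc(-c2ccon2)c2c(N)ncnc21`: > 10000 nM
Compound 2 `Nc1ncnc2c1c(-c1cc(C3CC3)on1)nn2C1CCCCC1`: > 10000 nM
Compound 3 `CC(C)(O)Cn1nc(-c2cc(C3CC3)on2)c2c(N)ncnc21`: > 10000 nM

In an ADME assay on BaF3 cells (Mus musculus) for cytotoxicity, read by MTT assay, with a stated time of 48 h (on this read-out higher numbers stand for weaker inhibition of growth and lower numbers for stronger inhibition of growth), compound 3 gives only a limit of the assay, > 10000 nM, and not a number. Among the measured compounds shown here, the series so far shows (the limit of > 10000 nM in this assay, at which 3 of the 3 values shown sit).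

The next compound to be tested is compound 4 `CCCCCCCn1nc(-c2cc(C3CC3)on2)c2c(N)ncnc21`. The change from compound 3 is hexyl in place of 1-hydroxy-1-methylethyl on a saturated chain carbon bound to an aromatic nitrogen.

For the measured compounds named here, only one measured step bears on this part of the molecule: a step that the two limits leave unreadable from compound 2 to compound 3, with 2-hydroxy-2-methylpropyl in place of cyclohexyl on an aromatic nitrogen. Its size cannot be read, so it offers no size or direction to carry over. Compound 2 is likewise only a limit, > 10000 nM. With no measured change to build on, no shift beyond the usual scatter is expected in this assay.

The expected step is a number no higher from compound 3 to compound 4 (the limit leaves the size open). For compound 4 the estimated value is 10000 nM, with an expected range of 5000 nM to 20000 nM.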

Compound 4, concentration for 50% growth inhibition: > 10000 nM
Compound 4 ended at the assay's limit; the forecaster's own chance of this, stated with the estimate: 80%; the middle value sits exactly at the limit.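

In this assay compound 4 gives > 10000 nM, which is a limit of the assay and not a number. The steps to compound 4 from compound 2 and compound 3 therefore cannot be read. The compounds shown leave open whether changing the group on the aromatic nitrogen alters growth inhibition at all.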